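The compounds below may be only part of what the source reports. "The series", "measured", "known", "first", "only" and "open" are said of these compounds alone.

Three compounds that share one core differ only in the group carried on an amine nitrogen. Compound 1 `CCC(C)NC(=C\C(=O)/C=C/c1ccc(O)c(OC)c1)/C=C/c1ccc(O)c(OC)c1` carries a sec-butyl group, compound 2 `C=CCNC(=C\C(=O)/C=C/c1ccc(O)c(OC)c1)/C=C/c1ccc(O)c(OC)c1` an allyl group and compound 3 `COc1cc(/C=C/C(=O)/C=C(/C=C/c2ccc(O)c(OC)c2)NC2CCCCC2)ccc1O` a cyclohexyl group. In a functional assay for inhibition, read by spectrophotometry, with a stated time of 30 min, tested at 1 uM (a higher number here means more inhibition at the concentration tested (going by the name of the read-out), a lower number less inhibition), compound 1 gives 0.13%, compound 2 gives 0.1% and compound 3 gives 0.13%. Compound 3 stands level with compound 1 at the digits shown, the two together being the highest of the three numbers, yet the steps of no change at the digits printed from compound 1 to compound 3 (within the scatter) and a number 0 percentage points higher from compound 2 to compound 3 (within the scatter) both lie within the scatter, so all three numbers sit together at the very bottom of the scale, with essentially no inhibition at the concentration tested.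

Compound 4 `COc1cc(/C=C/C(=O)/C=C(/C=C/c2ccc(O)c(OC)c2)NCC(C)C)ccc1O` has not yet been measured. It differs from compound 3 in one place: isobutyl in place of cyclohexyl on an amine nitrogen. Among the compounds with values here, the steps that bear on this change are the earlier swaps on the same nitrogen, no change at the digits printed from compound 1 to compound 3 (within the scatter), a number 0 percentage points higher from compound 2 to compound 3 (within the scatter) and a number 0 percentage points lower from compound 1 to compound 2 (within the scatter), each within the scatter. Since every swap at this nitrogen left the inhibition flat, no step beyond the scatter is expected in this assay here either; the expected step is a number 0 percentage points lower from compound 3 to compound 4 (within the scatter). Compound 4 is therefore estimated to give 0.12% in this assay, within a range from 0% to 5%.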

Compound 4, a percentage reported as inhibition, at one concentration (the size of the read-out at that concentration, not a potency): 0.09%
Estimate against measurement, compound 4: 0 percentage points above, within the range that was stated.
By their numbers in this assay, from the lowest: compounds 4, 2, 1 and 3 (each within the scatter of the next).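

In this assay the swap to isobutyl from cyclohexyl gives a number 0 percentage points lower from compound 3 to compound 4 (within the scatter) and so adds something the earlier swaps did not test: an open branched chain on the amine nitrogen, with no ring and fewer carbon atoms, reads the same as the six-membered carbon ring. The two remaining comparisons agree, with isobutyl in place of sec-butyl giving a number 0 percentage points lower from compound 1 to compound 4 (within the scatter) and the change from the allyl compound giving a number 0 percentage points lower from compound 2 to compound 4 (within the scatter) so neither the branching of the chain nor the double bond of allyl separates these compounds. All four numbers sit at the very bottom of the scale, so this flatness shows only that the inhibition in this assay is level across these groups at the concentration tested, and nothing at hand explains the result.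

The compounds shown leave open whether a different kind of group on this nitrogen, such as a phenyl ring, a much longer chain or a chain ending in a carboxylic acid, would lift the number off the bottom of the scale. They also leave open whether these four compounds would separate at a higher concentration.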